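Swapping a Cyclopentyl Urea for a Halogenated Aryl Urea

The compounds below may be only part of what the source reports. "The series", "measured", "known", "first", "only" and "open" are said of these compounds alone.

Compound 1 `Cc1ccc(NC(=O)Nc2cccc(CNc3nccnc3Cl)c2)cc1Cl` gives 11300 nM in a functional assay on HepG2 cells (Homo sapiens) for antiproliferative activity, read by MTT assay, with a stated time of 48 h; a lower number here means a stronger inhibitor, a higher number a weaker inhibitor.
Compound 2 `O=C(Nc1cccc(CNc2nccnc2Cl)c1)NC1CCCCC1` reaches only a limit in this assay, > 40000 nM.
Compound 3 `O=C(Nc1cccc(CNc2nccnc2Cl)c1)NC1CCCC1` gives 18400 nM in this assay.

Compound 3 holds the higher of the two real numbers shown, but the step of a 1.6-fold higher number from compound 1 to compound 3 (0.21 log units; within the scatter) means compound 1 and compound 3 cannot be told apart. Compound 2 stands at a limit, (the limit of > 40000 nM in this assay, at which 1 of the 3 values shown sits). The step of an at least 2.1-fold lower number from compound 2 to compound 3 (0.33 log units; beyond the scatter) therefore marks a genuine gain on going from the six-membered to the five-membered ring on the amide-type nitrogen.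

Compound 4 `O=C(Nc1cccc(CNc2nccnc2Cl)c1)Nc1ccc(F)c(Cl)c1` has not yet been measured. It differs from compound 3 in one place: 3-chloro-4-fluorophenyl in place of cyclopentyl on an amide-type nitrogen. The step that bears on this change most directly is a 1.6-fold higher number from compound 1 to compound 3 (0.21 log units; within the scatter), which swaps a chloro-methyl aryl group for cyclopentyl and stays within the scatter. A second halogenated aryl group is expected to behave much like compound 1, so the step of a 1.8-fold lower number from compound 3 to compound 4 (0.26 log units; within the scatter) is expected to be small and downward, not clearly beyond the scatter. Compound 4 is therefore estimated at 10000 nM, with a plausible range from 4000 nM to 25000 nM.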

Compound 4, half-maximal inhibitory concentration: 6750 nM
Estimate against measurement, compound 4: 1.5-fold (0.17 log units) above, within the range that was stated.
By their numbers in this assay, from the lowest: compounds 4, 1 and 3 (each within the scatter of the next, the first and the last beyond it). At a limit, above all of these: compound 2.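

Among these compounds, on the amide-type nitrogen, an aryl group now clearly differs from cyclopentyl for the first time, with a 2.7-fold lower number from compound 3 to compound 4 (0.44 log units; beyond the scatter) in this assay, whereas compound 1 stayed within the scatter of compound 3. Compound 2 is held at a limit, so the step of an at least 5.9-fold lower number from compound 2 to compound 4 (0.77 log units; beyond the scatter) gives only a minimum size for the gain over cyclohexyl: the limit of > 40000 nM in this assay, at which 1 of the 4 values shown sits. Between the two aryl ureas, fluoro in place of methyl on an aromatic carbon gives a 1.7-fold lower number from compound 1 to compound 4 (0.22 log units; within the scatter), so compound 1 and compound 4 cannot be told apart, and the clear separation from cyclopentyl rests on compound 4 alone, with compound 1 as the case against a general aryl advantage.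

The compounds shown leave open whether the chloro and fluoro substituents matter at all, a question that a plain phenyl group on the same nitrogen would address. They also leave open how a benzyl group or a longer chain such as n-butyl would compare with the rings seen here.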